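A few compounds are considered here, and "the series" means these few. Any claim that something is new, unique, unknown or untested is made for them only; others in the source may bear on it.

Measured compounds:
- compound 1 `C=CCc1c(O)ccc(C(=O)/C=C/c2ccc(O)cc2)c1O`: 73.4%
- compound 2 `O=C1CC(c2cccc(Br)c2)Oc2cc(O)cc(O)c21`: 93.5%
- compound 3 `C=CCc1c(O)cc(O)c2c1OC(c1cccc(Cl)c1)CC2=O`: 76.7%

In a functional assay on aorta (Rattus norvegicus, strain Sprague-Dawley) for inhibition, with a stated time of 20 min (on this read-out higher numbers stand for larger maximal responses and lower numbers for smaller maximal responses), compound 3 gives the second highest of the three numbers. Compound 1 lies close to it, the two values being within the scatter of each other, so no order between compound 3 and compound 1 can be claimed. Compound 2 gives a number beyond the scatter above compound 3; compound 2 carries a bromo group on its phenyl ring and has no allyl group on the core, so the two structures differ in more than one place and no single cause can be read from the pair.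

Compound 4 `C=CCc1c(O)cc(O)c2c1OC(c1cccc(O)c1)CC2=O` has not been measured in this assay. It is reached from compound 3 by the change (hydroxy in place of chloro on an aromatic carbon). Going by the values given here, no pair of measured compounds shows this same change, so its size is not known from the series. Compound 1 also carries a hydroxy group on its phenyl ring and gives a number close to compound 3, which points to a step of small size, downward if at all, and not beyond the scatter. The expected step from compound 3 to compound 4 is a number 4.7 percentage points lower from compound 3 to compound 4 (within the scatter). Compound 4 is therefore estimated at 72%, with a range from 58% to 86%.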

Compound 4, largest response reached (Emax), in percent of the reference or control that the assay uses: 97.8%
Estimate against measurement, compound 4: 25.8 percentage points below; the measured number lies above the stated range.
By their numbers in this assay, from the lowest: compounds 1 and 3 (each within the scatter of the next); then compounds 2 and 4 (each within the scatter of the next).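

In this assay, going by these compounds alone, going from 3-chlorophenyl to 3-hydroxyphenyl gives a number 21.1 percentage points higher from compound 3 to compound 4 (beyond the scatter), the first step between compounds that differ in one place. This position, on an aromatic carbon meta to a large group, therefore responds to the choice of group, and hydroxy in place of chloro moves the read-out upward beyond the scatter. The finding rests on this single pair, and no measurement at hand gives a reason for the step.

Still open, going by these compounds, is whether the step comes from the arrival of hydroxy or from the departure of chloro, since no other group at this position can be compared on the same core. On these data alone, a methoxy group or an amine at this place would help separate the two, and the same change on a core without the allyl group remains unknown.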